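Swapping the amine substituent on a shared pyrimidine core

The source may hold more compounds than are shown below. What is called first, only, known or untested is meant among the compounds shown, and "the series" means these compounds.

Measured so far:
- compound 1, `C=CC(=O)Nc1cc(Nc2ncc(Cl)c(Nc3cccc(C(F)(F)F)c3)n2)c(OC)cc1N1CCN(C)CC1`, 770 nM
- compound 2, `C=CC(=O)Nc1cc(Nc2ncc(Cl)c(NCc3cccs3)n2)c(OC)cc1N1CCN(C)CC1`, 270 nM
- compound 3, `C=CC(=O)Nc1cc(Nc2ncc(Cl)c(N(C)c3cccc(C(F)(F)F)c3)n2)c(OC)cc1N1CCN(C)CC1`, 3600 nM

The three compounds were compared in a functional assay on NCI-H3122 cells (Homo sapiens) for inhibition, read by CellTiter-Glo, with a stated time of 72 h; a lower number here means a stronger inhibitor of growth, a higher number a weaker inhibitor of growth. Compound 2 gives the lowest number of the three; compound 1 sits nearest to it, shown by a 2.9-fold lower number from compound 1 to compound 2 (0.46 log units; beyond the scatter), and compound 3 lies furthest away, shown by a 13-fold higher number from compound 2 to compound 3 (1.12 log units; beyond the scatter). The remaining step, a 4.7-fold higher number from compound 1 to compound 3 (0.67 log units; beyond the scatter), shows that adding a methyl on the nitrogen carrying the 3-(trifluoromethyl)phenyl costs potency.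

Compound 4, `C=CC(=O)Nc1cc(Nc2ncc(Cl)c(Nc3ccccc3S(=O)(=O)N(C)C)n2)c(OC)cc1N1CCN(C)CC1`, has not yet been measured in this assay. Its difference from compound 2 is 2-(dimethylsulfamoyl)phenyl in place of (thiophen-2-yl)methyl on a nitrogen on an aromatic ring. Among the compounds with values here, no measured step covers this exact exchange. The step from compound 1 to compound 2 is the closest guide, since it also changes the group on that same nitrogen, and it was modest in size. A return to an aryl group, now bearing a dimethylsulfamoyl, may therefore move the number modestly in either direction. Compound 4 is estimated at 300 nM, within 70 nM to 1300 nM, which is expected to amount to a 1.1-fold higher number from compound 2 to compound 4 (0.05 log units; within the scatter).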

Compound 4, concentration for 50% growth inhibition: 11 nM
Compound 4: middle estimate off by 27-fold (1.44 log units), on the high side; measured number outside the range, below it.
By their numbers in this assay, from the lowest: compound 4; then compound 2; then compound 1; then compound 3.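

Within the data shown here, on the nitrogen on the aromatic ring, the choice of group proved far more decisive than the earlier compounds showed: in this assay the exchange for 2-(dimethylsulfamoyl)phenyl gives a 25-fold lower number from compound 2 to compound 4 (1.39 log units; beyond the scatter) in this series. An aryl group on that nitrogen is therefore compatible with a low number, and what the ring carries matters greatly, as the comparison of two phenyl groups gives a 70-fold lower number from compound 1 to compound 4 (1.85 log units; beyond the scatter) between otherwise identical compounds. No measurement shown here accounts for the size of these steps.

Compound 4 alone carries a dimethylsulfamoyl, so the contribution of that group cannot be separated from that of the phenyl ring bearing it. Going by these compounds, it remains open whether a carboxylic acid or a primary amine in its place would keep the number in this assay as low, and whether a methyl on the nitrogen would raise it for compound 4 as it did for compound 3.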